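Free acid with isopropyl side chain: compound 4

A few compounds are considered here, and "the series" means these few. Any claim that something is new, unique, unknown or untested is made for them only; others in the source may bear on it.

Of the compounds shown here, three have been measured in a functional assay on the whole organism (Tail, strain ICR) with Mus musculus as the target, in the tail flick test, with a stated time of 150 min, at a dose of 25 umol/kg by the oral route; on this read-out lower numbers stand for a weaker effect and higher numbers for a stronger effect at the one dose given. Compound 1 `O=C(CN(c1nc(Cl)nc2[nH]cnc12)C1CC1)N[C@@H](CC(=O)OCc1ccccc1)C(=O)OCc1ccccc1` gives 6.68%, compound 3 `CC[C@H](C)[C@H](NC(=O)CN(c1nc(Cl)nc2[nH]cnc12)C1CC1)C(=O)OCc1ccccc1` gives 6.9%, and compound 2 `C[C@@H](O)[C@H](NC(=O)CN(c1nc(Cl)nc2[nH]cnc12)C1CC1)C(=O)O` gives 24%. Compound 2 stands highest of the three; the next number, that of compound 3, lies beyond the scatter below it, and compound 1 lies a little further down still. Among the measured compounds shown here, the only single-point step measured so far is a number 0.2 percentage points higher from compound 1 to compound 3 (within the scatter), a change at the same saturated chain carbon as the one considered here, but among benzyl esters rather than free acids.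

Compound 4 `CC(C)[C@H](NC(=O)CN(c1nc(Cl)nc2[nH]cnc12)C1CC1)C(=O)O` differs from compound 2 by isopropyl in place of 1-hydroxyethyl on a saturated chain carbon bound to an amide-type nitrogen and a carbonyl carbon. For the measured compounds named here, no measured pair isolates the loss of the hydroxyl on a free acid, and compound 2 differs from compound 1 and compound 3 in more than one place, so no step can be read off for the side chain alone. Going by the values given here, the one step at this position, from compound 1 to compound 3, was within the scatter, which argues for a small effect. Some fall is nevertheless allowed for, since the 1-hydroxyethyl group of compound 2 accompanies the only high number seen. The expected step is a number 7 percentage points lower from compound 2 to compound 4 (within the scatter). Compound 4 is thus estimated at 17%, within a range of 6% to 30%.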

Compound 4, a percentage reported as activity, at one dose (the size of the read-out at that dose, not a potency): 7.86%
Compound 4: middle estimate off by 9.1 percentage points, on the high side; the measured number falls inside the stated range.
By their numbers in this assay, from the lowest: compounds 1, 3 and 4 (each within the scatter of the next); then compound 2.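

In this assay, isopropyl in place of 1-hydroxyethyl on a saturated chain carbon bound to an amide-type nitrogen and a carbonyl carbon leaves the read-out a number 16.1 percentage points lower from compound 2 to compound 4 (beyond the scatter), so among free acids this position responds to the change. Among the compounds shown here, the one earlier step at this carbon, among benzyl esters and with other groups, came out as a number 0.2 percentage points higher from compound 1 to compound 3 (within the scatter), and that flat result does not carry over to this pair. The step goes with the loss of 1 hydrogen-bond donor, 1 hydrogen-bond acceptor and 1 defined stereocentre, but no measurement here explains it or separates these differences.

Open, as far as these compounds go, is whether 1-methoxyethyl or 1-aminoethyl on that carbon would stand with compound 2 or with compound 4. Also open, from the compounds shown here alone, is whether the same change among benzyl esters would give a comparable step.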